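Cytotoxicity notes: the step from compound 3 to compound 4

The source may hold more compounds than are shown below. What is called first, only, known or untested is meant among the compounds shown, and "the series" means these compounds.

In an ADME assay on MDBK cells (Bos taurus) for cytotoxicity, read by MTT assay, with a stated time of 96 h (a higher number here means that more compound is tolerated, a lower number that less compound is tolerated), compound 1 (`Cc1ccc(/N=N/N(C)c2ccccc2)cc1`) gives > 100000 nM, which is a limit of the assay and not a number. Compound 2 (`Clc1cccc(/N=N/N2CCCC2)c1`) gives > 100000 nM, again a limit of the assay. Going by the values given here, compound 3 (`Fc1ccc(F)c(/N=N/c2ccc(NC[C@@H]3CCCN4CCCC[C@H]34)c3c2CCCC3)c1`) gives 64000 nM, the only actual number so far. Compound 4 (`c1ccc(/N=N/c2ccc(NC[C@@H]3CCCN4CCCC[C@H]34)c3c2CCCC3)cc1`) carries phenyl in place of 2,5-difluorophenyl on a double-bonded nitrogen. Among the compounds with values here, no measured pair shows this change, so the expectation rests on compound 3 at 64000 nM. The expected step, a 1.0-fold higher number from compound 3 to compound 4 (0.01 log units; within the scatter), is no larger than the scatter in this assay. Compound 4 is estimated at 65000 nM, with an expected range from 32000 nM to 100000 nM.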

Compound 4, half-maximal cytotoxic concentration: > 100000 nM
Compound 4: only a limit was reported (the forecaster's own chance of this, stated with the estimate: 30%); middle value at least 1.5-fold (0.18 log units) from the limit.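

In this assay, going by these compounds alone, the first one-place comparison, phenyl in place of 2,5-difluorophenyl on a double-bonded nitrogen gives an at least 1.5-fold higher number from compound 3 to compound 4 (0.19 log units; that floor lies within the scatter). Compound 4 gives > 100000 nM, a limit of the assay and not a number. The true size of the step stays unknown, and the data do not settle whether it exceeds the scatter, because the reading is capped: the limit of > 100000 nM in this assay, at which 3 of the 4 values shown sit.

Open, from the compounds shown here alone, is whether a single fluorine, a methoxy or a carboxylic acid in this place would give a value that can be read as a number. Also open, going by these compounds, is whether any change here would give a clear step.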